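Working notes: compound 4 against the measured series

A few compounds are considered here, and "the series" means these few. Any claim that something is new, unique, unknown or untested is made for them only; others in the source may bear on it.

Compound 1 `CCOC(=O)c1c(-c2cccc(C)c2)[nH]c2cc(OC)ccc2c1=O` gives > 22000 nM in an ADME assay on HEK293 cells (Homo sapiens) for cytotoxicity, read by luminescence, with a stated time of 72 h (on this read-out higher numbers stand for an effect only at larger amounts of compound and lower numbers for an effect already at smaller amounts), which is a limit of the assay.
Compound 2 `CCOC(=O)c1c(-c2cccc(OC(C)C)c2)[nH]c2cc(OC)ccc2c1=O` gives > 22000 nM in this assay, again a limit.
Compound 3 `CCOC(=O)c1c(-c2cccc(C(F)(F)F)c2)[nH]c2cc(OC)ccc2c1=O` gives > 22000 nM in this assay, also a limit.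

Compound 3 therefore stands at the limit of > 22000 nM in this assay, at which 3 of the 3 values shown sit, and no measured value separates it from the others. The steps a step that the two limits leave unreadable from compound 1 to compound 2, a step that the two limits leave unreadable from compound 1 to compound 3 and a step that the two limits leave unreadable from compound 2 to compound 3 are all unreadable for the same reason.

Compound 4 `CCOC(=O)c1c(-c2cccc(CO)c2)[nH]c2cc(OC)ccc2c1=O` differs from compound 3 by hydroxymethyl in place of trifluoromethyl on an aromatic carbon. For the measured compounds named here, no measured step bears readably on this change; every value so far sits at the limit. The expectation for compound 4 in this assay is accordingly a step that the limit leaves unreadable from compound 3 to compound 4, that is, none that the assay would resolve. Compound 4 is estimated at 30000 nM, within 15000 nM to 60000 nM, most likely reported again only as a limit.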

Compound 4, half-maximal effective concentration: > 22000 nM
Compound 4: only a limit was reported; the forecaster's own chance of this, stated with the estimate: 85%; the middle value does not contradict the limit.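

Compound 4 gives no readable step against compound 1, compound 2 or compound 3, since each value is only a limit: the limit of > 22000 nM in this assay, at which 4 of the 4 values shown sit.

From the compounds shown here alone, whether any group on the shared core gives a measurable effect in this assay stays open.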